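A few compounds are considered here, and "the series" means these few. Any claim that something is new, unique, unknown or untested is made for them only; others in the source may bear on it.

Measured so far in a functional assay on HepG2 cells (Homo sapiens) for inhibition, read by MTT assay, with a stated time of 48 h (on this read-out higher numbers stand for weaker inhibition and lower numbers for stronger inhibition), are three compounds that share one core.

- compound 1 (`COc1ccc(N(C)c2nc(C)nc3ccccc23)cc1OCCCC[Se]C#N`): 6460 nM
- compound 2 (`COc1ccc(N(C)c2nc(C)nc3ccccc23)cc1[Se]C#N`): 59 nM
- compound 3 (`COc1ccc(N(C)c2nc(C)nc3ccccc23)cc1C[Se]C#N`): 1110 nM

Compound 3 stands in the middle of these three numbers. On one side lies a 19-fold higher number from compound 2 to compound 3 (1.27 log units; beyond the scatter) and on the other 5.8-fold lower number from compound 1 to compound 3 (0.76 log units; beyond the scatter) in the opposite direction.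

Compound 4 (`COc1ccc(N(C)c2nc(C)nc3ccccc23)cc1OCCCCC[Se]C#N`) has not been measured yet. It differs from compound 3 in one group: a group of 9 heavy atoms (6 carbon, 1 nitrogen, 1 oxygen, 1 selenium; no ring) in place of a group of 4 heavy atoms (2 carbon, 1 nitrogen, 1 selenium; no ring), on an aromatic carbon. The exchange happens on an aromatic carbon, ortho to a methoxy group.

Across the three measured compounds, the number rises as the group on that carbon grows, and none of them goes against this. The widest gap is a 110-fold lower number from compound 1 to compound 2 (2.04 log units; beyond the scatter) in the lower direction. Three compounds are thin evidence, though. Among the compounds with values here, compound 1 carries the group most like the one entering in compound 4, and compound 1 gives 6460 nM. The best guide is therefore a 5.8-fold lower number from compound 1 to compound 3 (0.76 log units; beyond the scatter), read backwards. The expected change is a 6.3-fold higher number from compound 3 to compound 4 (0.80 log units; beyond the scatter), an upward step of modest size in this assay. Within the data shown here, no measured compound carries a group this large, so the range is kept wide on the upper side. Compound 4 is estimated at 7000 nM (expected range 2500 nM to 20000 nM).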

Compound 4, half-maximal inhibitory concentration: 5210 nM
Compound 4: middle estimate off by 1.3-fold (0.13 log units), on the high side; low and high end bracket the measured number.
By their numbers in this assay, from the lowest: compound 2; then compound 3; then compounds 4 and 1 (each within the scatter of the next).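

In this assay, the larger group of compound 4 keeps the upward trend seen earlier, with a 4.7-fold higher number from compound 3 to compound 4 (0.67 log units; beyond the scatter) and, against the smallest group, an 88-fold higher number from compound 2 to compound 4 (1.95 log units; beyond the scatter). What is new is a pair that differs only in the length of the saturated chain joined through oxygen: a 1.2-fold lower number from compound 1 to compound 4 (0.09 log units; within the scatter). The earlier rule that the number rises as the group grows therefore does not hold between compound 1 and compound 4, since making the chain longer here produces no change beyond the scatter, although this flat stretch rests on these two compounds alone.

Nothing measured here explains why the number climbs from the shortest groups to the chains joined through oxygen, or why it then stays level between those two chains. From the compounds shown here alone, it also remains open whether a longer chain on that oxygen would stay in the same range, and whether an amine or a carboxylic acid in place of the selenium-bearing chain end would keep any of the inhibition.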